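The source may report more compounds than this note shows. Statements on the series, on what has been measured and on what is new or still open speak of the compounds shown alone.

Compounds measured in a functional assay on HeLa cells for agonist activity at 5-hydroxytryptamine receptor 6 (Homo sapiens), read by cAMP accumulation and immunoassay; on this read-out higher numbers stand for larger maximal responses and lower numbers for smaller maximal responses: compound 1 `CN1CCC(n2cc(S(=O)(=O)c3ccccc3)c3cccnc32)C1` gives 61%; compound 2 `O=S(=O)(c1ccccc1)c1cn(C2CCCNC2)c2ncccc12` gives 56%; compound 3 `CN1CCCC(n2cc(S(=O)(=O)c3cccc(C(F)(F)F)c3)c3cccnc32)C1` gives 66%.

Within the data shown here, compound 2 stands lowest of the three numbers in this assay, but its nearest neighbour is compound 1, and the only measured single-place step, a number 5 percentage points lower from compound 1 to compound 2 (within the scatter), stays within the scatter. Compound 3 lies furthest from compound 2, and that gap too is within the scatter, so the three measured compounds cannot be ordered.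

Compound 4 `O=S(=O)(c1cc(Cl)cc(Cl)c1)c1cn(C2CCCNC2)c2ncccc12` has not yet been measured. It differs from compound 2 in one place: 3,5-dichlorophenyl in place of phenyl on a sulfonyl sulfur. Among the measured compounds shown here, no measured step touches the group on the sulfonyl sulfur: the one measured step changes the substituent on the aromatic nitrogen instead, and compound 3, which carries a substituted phenyl on that sulfur, differs from compound 1 in two places at once, so its value says only that a substituted phenyl there gave a number within the scatter of the unsubstituted one. On this basis compound 4 is expected to show no step beyond the scatter, a number 4 percentage points higher from compound 2 to compound 4 (within the scatter). Compound 4 is therefore estimated at 60%, with a range from 45% to 75%.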

Compound 4, largest response reached (Emax), in percent of the reference or control that the assay uses: 62%
For compound 4 the middle estimate is 2 percentage points below the measured one; the measured number falls inside the stated range.
By their numbers in this assay, from the lowest: compounds 2, 1, 4 and 3 (each within the scatter of the next).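

In this assay the exchange of phenyl for 3,5-dichlorophenyl on the sulfonyl sulfur gives a number 6 percentage points higher from compound 2 to compound 4 (within the scatter) and so provides the first single-place step read directly at this position, where compound 3 had changed two places at once. Among these compounds, therefore, the added pair of chlorine atoms leaves the maximal response within the scatter of the unsubstituted phenyl, on the piperidin-3-yl series. No measured evidence is available to explain this result.

As far as these compounds go, whether this tolerance extends to other groups on that phenyl, such as a methoxy group, an amine or a single chlorine, remains open. Also open, from the compounds shown here alone, is whether 3,5-dichlorophenyl would behave the same way with 1-methylpyrrolidin-3-yl on the aromatic nitrogen.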